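The source may report more compounds than this note shows. Statements on the series, on what has been measured and on what is new or still open speak of the compounds shown alone.

In a functional assay on HCT-116 cells (Homo sapiens) for antiproliferative activity, read by MTT assay, with a stated time of 24 h (a lower number here means a stronger inhibitor, a higher number a weaker inhibitor), compound 1 `C=CCOc1ccc2c(=O)c(-c3cc(OC)c(OC)cc3OC)coc2c1` gives 6600 nM, compound 2 `COc1cc(OC)c(-c2coc3cc(OCc4ccc(F)cc4)ccc3c2=O)cc1OC` gives 950 nM and compound 3 `COc1cc(OC)c(-c2coc3cc(OCc4ccc(Br)cc4)ccc3c2=O)cc1OC` gives 1980 nM, so compound 3 holds the middle of the three numbers. The next change leads to compound 4 `COc1cc(OC)c(-c2coc3cc(OCc4ccc(C#N)cc4)ccc3c2=O)cc1OC`, with cyano in place of bromo on an aromatic carbon, para to a large group (cyano in place of bromo on an aromatic carbon). Going by the values given here, no measured step involves cyano. The closest is the exchange of fluoro for bromo, with a 2.1-fold higher number from compound 2 to compound 3 (0.32 log units; beyond the scatter). The steps of a 6.9-fold lower number from compound 1 to compound 2 (0.84 log units; beyond the scatter) and a 3.3-fold lower number from compound 1 to compound 3 (0.52 log units; beyond the scatter) replace vinyl and say less about this change. Only a small step is therefore expected, a 1.3-fold lower number from compound 3 to compound 4 (0.12 log units; within the scatter). For compound 4 the estimated value is 1500 nM, with an expected range of 600 nM to 3800 nM.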

Compound 4, half-maximal inhibitory concentration: 4220 nM
Compound 4: middle estimate off by 2.8-fold (0.45 log units), on the low side, and the stated range ends below it.
By their numbers in this assay, from the lowest: compound 2; then compound 3; then compounds 4 and 1 (each within the scatter of the next).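

In this assay, the group on this aromatic carbon, para to a large group, proves able to shift the number beyond the scatter in the direction the halogen exchange did not foretell for cyano: a 2.1-fold higher number from compound 3 to compound 4 (0.33 log units; beyond the scatter), and a 4.4-fold higher number from compound 2 to compound 4 (0.65 log units; beyond the scatter). The gain that 4-fluorophenyl and 4-bromophenyl showed in place of vinyl is not kept by 4-cyanophenyl, since a 1.6-fold lower number from compound 1 to compound 4 (0.19 log units; within the scatter) stays within the scatter. No available evidence bears on why this is so. The compounds shown leave open how a methoxy group or an amine on this same aromatic carbon would compare.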